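Swapping one aryl group on the shared core

A few compounds are considered here, and "the series" means these few. Any claim that something is new, unique, unknown or untested is made for them only; others in the source may bear on it.

Compound 1 `COc1cccc(-c2nn(-c3ccccc3)cc2C(Nc2nc3ccccc3s2)c2c(O)ccc3ccccc23)c1`: 16900 nM
Compound 2 `COc1ccc2nc(NC(c3cn(-c4ccccc4)nc3-c3ccc(F)cc3)c3c(O)ccc4ccccc34)sc2c1`: 16900 nM
Compound 3 `Oc1ccc2ccccc2c1C(Nc1nc2ccc(Cl)cc2s1)c1cn(-c2ccccc2)nc1-c1ccc(F)cc1`: 21600 nM

In a functional assay on MCF7 cells (Homo sapiens) for antiproliferative activity, read by MTT assay, with a stated time of 48 h (on this read-out lower numbers stand for stronger inhibition and higher numbers for weaker inhibition), compound 3 lies within the usual scatter of both compound 1 and compound 2, so these three numbers cannot be ranked. Compound 4 `COc1cccc(-c2nn(-c3ccccc3)cc2C(Nc2nc3ccc(Cl)cc3s2)c2c(O)ccc3ccccc23)c1` keeps the chloro group of compound 3 but carries 3-methoxyphenyl in place of 4-fluorophenyl on an aromatic carbon of the five-membered aromatic ring with 2 nitrogen.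

Going by the values given here, no measured step makes this exact swap. Among the compounds with values here, the only measured step, a 1.3-fold higher number from compound 2 to compound 3 (0.11 log units; within the scatter), concerns the exchange of chloro for methoxy elsewhere and stays within the scatter. The two groups also appear in compounds that differ in more than one place: compound 1, with 3-methoxyphenyl, gives 16900 nM and compound 2, with 4-fluorophenyl, gives 16900 nM in the same assay. On these values, no change beyond the scatter is expected in this assay.

The expected change is a 1.1-fold lower number from compound 3 to compound 4 (0.06 log units; within the scatter) (an estimate). Compound 4 is estimated at 19000 nM (expected range 10000 nM to 36000 nM).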

Compound 4, half-maximal inhibitory concentration: 36000 nM
Beside the measured number, compound 4's estimate is 1.9-fold (0.28 log units) below it, and the stated range covers the measured number.
By their numbers in this assay, from the lowest: compounds 1, 2, 3 and 4 (each within the scatter of the next, the first and the last beyond it).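

In this assay, the exchange of 4-fluorophenyl for 3-methoxyphenyl on this aromatic carbon can now be read directly (a 1.7-fold higher number from compound 3 to compound 4 (0.22 log units; within the scatter)), and this step stays within the scatter. With 3-methoxyphenyl at this position, chloro in place of hydrogen gives a modest step beyond the scatter (a 2.1-fold higher number from compound 1 to compound 4 (0.33 log units; beyond the scatter)), the only step among these compounds to pass that limit. No available measurement explains either step.

The compounds shown carry only these two aryl groups at this position, so the effect of a smaller or quite different group, such as a methyl group, a carboxylic acid or an amine, remains open. From the compounds shown here alone, whether chloro in place of hydrogen gives a similar step alongside 4-fluorophenyl also remains open.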